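A Carboxyphenyl Amide Tested Against Three Measured Analogues

A few compounds are considered here, and "the series" means these few. Any claim that something is new, unique, unknown or untested is made for them only; others in the source may bear on it.

Three compounds carrying the shared core have been measured in a functional assay on CLL cells (Homo sapiens) for cytotoxicity, read by MTT assay, with a stated time of 48 h; a lower number here means that less compound is needed, a higher number that more compound is needed for the effect:

Compound 1 `C=C(CC)C(=O)c1ccc(OCC(=O)Nc2ccc3c(C)cc(=O)oc3c2)c(Cl)c1Cl`, 2800 nM
Compound 2 `C=C(CC)C(=O)c1ccc(OCC(=O)Nc2ccc(C(N)=O)cc2)c(Cl)c1Cl`, 3700 nM
Compound 3 `C=C(CC)C(=O)c1ccc(OCC(=O)Nc2ccc(C(=O)OC)cc2)c(Cl)c1Cl`, 4100 nM

Compound 2 stands between its two neighbours, yet its distance to compound 3 and its distance to compound 1 both fall within the usual scatter, so the three values cannot be told apart. Going by the values given here, the one single-point step available, a 1.1-fold higher number from compound 2 to compound 3 (0.04 log units; within the scatter), shows a methoxy in place of amino on a carbonyl carbon leaving the read-out unchanged within the scatter.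

Compound 4 `C=C(CC)C(=O)c1ccc(OCC(=O)Nc2cccc(C(=O)O)c2)c(Cl)c1Cl` has not been measured. Its change from compound 2 is 3-carboxyphenyl in place of 4-carbamoylphenyl on an amide-type nitrogen. Among the compounds with values here, no measured step tests this change, and the only related step, a 1.1-fold higher number from compound 2 to compound 3 (0.04 log units; within the scatter), moves the read-out by nothing beyond the scatter. Compound 4 is therefore expected to give a step of a 1.2-fold higher number from compound 2 to compound 4 (0.09 log units; within the scatter), with no direction beyond the scatter. The estimated value for compound 4 is 4500 nM, in a range from 2000 nM to 10000 nM.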

Compound 4, half-maximal effective concentration: 20600 nM
Beside the measured number, compound 4's estimate is 4.6-fold (0.66 log units) below it; the whole stated range lies below it.
By their numbers in this assay, from the lowest: compounds 1, 2 and 3 (each within the scatter of the next); then compound 4.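

In this assay, going by these compounds alone, the substituent on the amide-type nitrogen is the first place where a change reaches beyond the scatter: 3-carboxyphenyl in place of 4-carbamoylphenyl gives a 5.6-fold higher number from compound 2 to compound 4 (0.75 log units; beyond the scatter). Compound 1, compound 2 and compound 3 gave no hint of this, as their values could not be told apart and the methoxy for amino exchange, a 1.1-fold higher number from compound 2 to compound 3 (0.04 log units; within the scatter), left the read-out unchanged within the scatter. Nothing available accounts for the size of the new step.

This single step changes both the group and its place on the ring, so it cannot show which of the two goes with the higher number. On these data alone, how a sulfonamide or an aminomethyl group on the same ring would read also stays open.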